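The compounds below may be only part of what the source reports. "The series", "measured", "known", "first", "only" and "open" are said of these compounds alone.

Compound 3 `Cc1csc2cc([C@H](C)Nc3ncnc(N)c3C#N)c(Cc3cccc(CN)c3)c(=O)n12` carries a 3-(aminomethyl)benzyl group on the shared core. In an ADME assay on the whole organism (lung, Rattus norvegicus) for metabolic stability, read by LC-MS (on this read-out lower numbers stand for a shorter-lived compound and higher numbers for a longer-lived compound), compound 3 gives 1.6 h. Compound 1 `Cc1csc2cc([C@H](C)Nc3ncnc(N)c3C#N)c(-c3ccccc3)c(=O)n12` in this assay gives < 0.1 h, which is a limit of the assay, so compound 1 sits at the limit of < 0.1 h in this assay, at which 1 of the 3 values shown sits. Compound 2 `Cc1csc2cc([C@H](C)Nc3ncnc(N)c3C#N)c(Cc3cccc(CN(C)CC(C)C)c3)c(=O)n12` in this assay gives 2.3 h. Two steps lead to compound 3: an at least 16-fold higher number from compound 1 to compound 3 (1.20 log units; beyond the scatter), and a 1.4-fold lower number from compound 2 to compound 3 (0.16 log units; within the scatter). Of the two numbers shown, compound 3 has the lowest, with compound 2 nearest and within the scatter.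

Compound 4 `Cc1csc2cc([C@H](C)Nc3ncnc(N)c3C#N)c(Cc3cccc(CN(C)C)c3)c(=O)n12` is not yet measured. It differs from compound 3 as follows: dimethylamino in place of amino on a saturated chain carbon bound to an aromatic carbon. Within the data shown here, the step that bears on this change is the one from compound 2 to compound 3, where a different substituent at the same place moved the number only within the scatter. The large step from compound 1 to compound 3 altered a different part of the molecule and gives no guidance here. No step beyond the scatter is therefore expected in this assay. Compound 4 is expected to give 1.9 h, with a range from 0.9 h to 4 h. The expected step is a 1.2-fold higher number from compound 3 to compound 4 (0.07 log units; within the scatter).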

Compound 4, half-life: 2.3 h
Compound 4: middle estimate off by 1.2-fold (0.08 log units), on the low side, and the stated range covers the measured number.
By their numbers in this assay, from the lowest: compounds 3, 2 and 4 (each within the scatter of the next). At a limit, below all of these: compound 1.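

In this assay, the amine at this place on the saturated chain carbon bound to an aromatic carbon now reads alike across amino, dimethylamino and isobutyl(methyl)amino: a 1.4-fold higher number from compound 3 to compound 4 (0.16 log units; within the scatter), and no change at the digits printed from compound 2 to compound 4 (within the scatter). The large separation from the phenyl compound also holds for this third amine, with an at least 23-fold higher number from compound 1 to compound 4 (1.36 log units; beyond the scatter). That step starts from a limit and not from a number, as compound 1 stands at the limit of the assay: the limit of < 0.1 h in this assay, at which 1 of the 4 values shown sits.

Going by these compounds, it remains open whether a hydroxyl, a carboxylic acid or a cyclic amine such as morpholine on the same carbon would read like these amines. The step from compound 1 also combines the change from phenyl to benzyl with the added amine, and the compounds shown do not separate the two.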